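The source may hold more compounds than are shown below. What is called first, only, known or untested is meant among the compounds shown, and "the series" means these compounds.

Measured so far:
Compound 1 `CC1=NN(C(=O)CN2CCC(c3ccccc3)CC2)C(c2ccccc2O)C1` — 23300 nM
Compound 2 `O=C(CNC1CC1)N1N=C(c2cc3ccccc3oc2=O)CC1c1ccccc1` — "not active" (no number reported)

In a functional assay on HepG2 cells (Homo sapiens) for cytotoxicity, read by MTT assay, with a stated time of 48 h (on this read-out higher numbers stand for weaker inhibition and lower numbers for stronger inhibition), compound 1 gives 23300 nM, a weak result. Compound 2 gives "not active" (no number reported), so no number stands for it, only the statement that inhibition was not seen. Compound 3 `NC(=O)C1CCN(CC(=O)N2N=C(c3cc4ccccc4oc3=O)CC2c2ccccc2)CC1` differs from compound 2 in one place: 4-carbamoylpiperidin-1-yl in place of cyclopropylamino on a saturated chain carbon bound to a carbonyl carbon. Going by the values given here, no measured pair shows what this change does, so the direction of the step is unknown; given that compound 2 shows "not active" (no number reported), nothing suggests compound 3 will become a strong inhibitor. Compound 3 is expected to give about 40000 nM, within 10000 nM to 150000 nM, and may again return no number.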

Compound 3, half-maximal inhibitory concentration: 19300 nM
The estimate for compound 3 lay 2.1-fold (0.32 log units) above the measured number, and the stated range covers the measured number.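

Going by these compounds alone, compound 2 has no number, so no step from it to compound 3 can be read. As far as these compounds go, whether 4-carbamoylpiperidin-1-yl in place of cyclopropylamino strengthens or weakens inhibition stays open. No supporting measurement bears on this result.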